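A few compounds are considered here, and "the series" means these few. Any claim that something is new, unique, unknown or untested is made for them only; others in the source may bear on it.

- compound 1 `NS(=O)(=O)c1ccc(/C=C/c2ccc(F)cc2)cc1`: 20900 nM
- compound 2 `NS(=O)(=O)c1ccc(/C=C/c2cccc(O)c2)cc1`: 30200 nM

Both compounds were tested in a functional assay on IGROV-1 cells (Homo sapiens) for inhibition; on this read-out lower numbers stand for stronger inhibition of growth and higher numbers for weaker inhibition of growth. Compound 1 gives 20900 nM and compound 2 gives 30200 nM. Among the compounds with values here, these two values lie within the usual scatter of each other, so compound 1 stands level with the only other measured compound, and both sit in the same high range of the scale.

The next compound, not yet measured, is compound 3 `CN(C)c1ccc(/C=C/c2ccc(S(N)(=O)=O)cc2)cc1`. It differs from compound 1 by a single change: dimethylamino in place of fluoro on an aromatic carbon. In plain terms, dimethylamino stands in place of fluoro on an aromatic carbon, para to a large group.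

Within the data shown here, no measured pair shows what a change at this place does, so the data offer no step to carry over. Among the measured compounds shown here, the only guide is the closeness of compound 2 at 30200 nM to compound 1 at 20900 nM. The expected result is a 1.5-fold lower number from compound 1 to compound 3 (0.17 log units; within the scatter), a slight move towards a lower number that is not expected to exceed the scatter. For compound 3 the estimated value is 14000 nM, with an expected range from 4000 nM to 40000 nM.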

Compound 3, concentration for 50% growth inhibition: 13400 nM
For compound 3 the middle estimate is 1.0-fold (0.02 log units) above the measured one; the range from low to high includes it.
By their numbers in this assay, from the lowest: compounds 3, 1 and 2 (each within the scatter of the next, the first and the last beyond it).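

In this assay, within the data shown here, the first step at this position is a 1.6-fold lower number from compound 1 to compound 3 (0.19 log units; within the scatter), obtained with dimethylamino in place of fluoro on an aromatic carbon, para to a large group. This shows that the swap, which brings in a larger group with a hydrogen-bond acceptor where the fluoro group counts none, leaves the read-out within the scatter, so for this one pair the number does not separate the two substituents and the position tolerates both without a measurable shift. Among these compounds, no accompanying measurement offers an explanation for this outcome, and the single pair gives no basis for a trend across substituents at this place.

From the compounds shown here alone, whether a primary amine, a methoxy group, a carboxylic acid or a longer chain such as diethylamino on the same aromatic carbon would give a step beyond the scatter remains open. Going by these compounds, it also remains open whether any such group could bring the number out of the high range in which compound 1 and compound 3 both sit.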